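The compounds below may be only part of what the source reports. "The series", "measured", "known", "first", "only" and "open" are said of these compounds alone.

Measured compounds and their values in an assay on CHO-K1 cells for displacement of a labelled ligand from adenosine receptor A1 (Homo sapiens), read by scintillation counting, with a stated time of 60 min; a higher number here means a weaker inhibitor, a lower number a stronger inhibitor:

Compound 1 `Nc1nc(N/N=C/c2ccc[nH]2)nc2c1ncn2[C@@H]1O[C@H](CO)[C@@H](O)[C@H]1O` gives 8 nM.
Compound 2 `Nc1nc(N/N=C/c2ccc(Cl)c(C(F)(F)F)c2)nc2c1ncn2[C@@H]1O[C@H](CO)[C@@H](O)[C@H]1O` gives > 10000 nM, which is a limit of the assay and not a number.
Compound 3 `COc1ccc(/C=N/Nc2nc(N)c3ncn([C@@H]4O[C@H](CO)[C@@H](O)[C@H]4O)c3n2)cn1` gives 2.6 nM.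

Among the two numbers shown, compound 3 has the lowest; the only other number belongs to compound 1, and that step is a 3.1-fold lower number from compound 1 to compound 3 (0.49 log units; beyond the scatter). One of the three values shown is the limit of > 10000 nM in this assay, at which 1 of the 3 values shown sits.

Compound 4 `CN(C)c1ccc(/C=N/Nc2nc(N)c3ncn([C@@H]4O[C@H](CO)[C@@H](O)[C@H]4O)c3n2)cc1` differs from compound 3 in one place: 4-(dimethylamino)phenyl in place of 6-methoxypyridin-3-yl on a carbon with a double bond to nitrogen. Among the compounds with values here, no measured step swaps these two groups directly. What the measured steps do show is that the group on the carbon with a double bond to nitrogen can move the number a great deal or only a little: an at least 1200-fold higher number from compound 1 to compound 2 (3.09 log units; beyond the scatter) and an at least 3800-fold lower number from compound 2 to compound 3 (3.58 log units; beyond the scatter) were large, whereas a 3.1-fold lower number from compound 1 to compound 3 (0.49 log units; beyond the scatter) was modest. Compound 3 and compound 1 both carry small aromatic groups with a single hetero atom and stay low; the heavily halogenated group of compound 2 sits at the limit. A dimethylamino-bearing phenyl looks closer to the former pair than to compound 2, so a modest shift is expected.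

Compound 4 is expected to give about 10 nM, within 1.5 nM to 150 nM. The expected step is a 3.8-fold higher number from compound 3 to compound 4 (0.59 log units; beyond the scatter).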

Compound 4, inhibition constant: > 10000 nM
Compound 4 ended at the assay's limit; the forecaster's own chance of this, stated with the estimate: 10%; middle value at least 1000-fold (3.00 log units) away from the limit.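

In this assay, putting 4-(dimethylamino)phenyl on the carbon with a double bond to nitrogen brings an at least 3800-fold higher number from compound 3 to compound 4 (3.58 log units; beyond the scatter) and an at least 1200-fold higher number from compound 1 to compound 4 (3.09 log units; beyond the scatter). A phenyl group without any halogen can therefore also end far from the low numbers, and among these four compounds, the two with low numbers, compound 1 and compound 3, are the two with a hetero atom in this aromatic ring. The result for compound 4 is a limit of the assay and not a number, so its step to compound 2 cannot be read: the limit of > 10000 nM in this assay, at which 2 of the 4 values shown sit.

As far as these compounds go, it remains open whether the ring's hetero atom, the group attached to the ring, or both decide the outcome. A 4-methoxyphenyl group and a 6-(dimethylamino)pyridin-3-yl group would each change one of these features while keeping the other.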